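Propargyl Ester in Place of Cyclohexylethyl on a Free Sugar

This account rests on a few compounds, and the source may have more. Where it says the series, first, only, none or still open, it means among the compounds named here.

Of the compounds shown here, three have been measured in a functional assay on SK-BR-3 cells (Homo sapiens) for antiproliferative activity, read by MTT assay, with a stated time of 72 h; on this read-out higher numbers stand for weaker inhibition and lower numbers for stronger inhibition. Compound 1, `C#CCOC(=O)C[C@@H]1C(C(=O)OC)=CO[C@@H](O[C@@H]2O[C@H](COC(C)=O)[C@@H](OC(C)=O)[C@H](OC(C)=O)[C@H]2OC(C)=O)/C1=C/C`, carries a propargyl ester and a fully acetylated sugar. In this assay compound 1 gives only a limit, > 15000 nM. Compound 2, `C/C=C1/[C@H](O[C@@H]2O[C@H](COC(C)=O)[C@@H](OC(C)=O)[C@H](OC(C)=O)[C@H]2OC(C)=O)OC=C(C(=O)OC)[C@H]1CC(=O)OCCC1CCCCC1`, keeps the same acetylated sugar but bears a 2-cyclohexylethyl ester instead. In this assay compound 2 likewise reaches only a limit, > 15000 nM. Among the compounds with values here, compound 3, `C/C=C1/[C@H](O[C@@H]2O[C@H](CO)[C@@H](O)[C@H](O)[C@H]2O)OC=C(C(=O)OC)[C@H]1CC(=O)OCCC1CCCCC1`, keeps the 2-cyclohexylethyl ester of compound 2 but has a sugar with free hydroxyl groups; in this assay compound 3 gives 2000 nM, the only number among the three. How compound 3 differs from compound 2 is not broken down here.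

The change from compound 2 to compound 1 is ethynyl in place of cyclohexylmethyl on a saturated chain carbon bound to an oxygen next to a carbonyl group, and the step it made is a step that the two limits leave unreadable from compound 2 to compound 1, since both ends sit at the limit of > 15000 nM in this assay, at which 2 of the 3 values shown sit.

Compound 4, `C#CCOC(=O)C[C@@H]1C(C(=O)OC)=CO[C@@H](O[C@@H]2O[C@H](CO)[C@@H](O)[C@H](O)[C@H]2O)/C1=C/C`, is not yet measured. It differs from compound 3 by ethynyl in place of cyclohexylmethyl on a saturated chain carbon bound to an oxygen next to a carbonyl group, the same change that turned compound 2 into compound 1, at the same place. The earlier step gives no readable size, so the expectation for compound 4 rests on compound 3 at 2000 nM and on the loss of the cyclohexylmethyl group. The step from compound 3 to compound 4 is expected to be a 3.0-fold higher number from compound 3 to compound 4 (0.48 log units; beyond the scatter), a weakening. Compound 4 is estimated at 6000 nM, with a range from 1500 nM to 20000 nM, and a fair chance that only a limit is reported.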

Compound 4, half-maximal inhibitory concentration: > 15000 nM
Compound 4 gave a limit, no number; the forecaster's own chance of this, stated with the estimate: 35%; at least 2.5-fold (0.39 log units) between middle value and limit.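

In this assay, going from the 2-cyclohexylethyl ester to the propargyl ester on the core with the free sugar gives an at least 7.5-fold higher number from compound 3 to compound 4 (0.87 log units; beyond the scatter), a clear weakening on this core. As far as these compounds go, compound 4 gives > 15000 nM, which is a limit and not a number, so the full size of this weakening stays unknown. The change therefore has one readable case, and whether the same step carries over to the core with the acetylated sugar is not shown, because both ends of that step, from compound 2 to compound 1, sit at a single limit: the limit of > 15000 nM in this assay, at which 3 of the 4 values shown sit.

The change takes away the six-membered ring and brings in a triple bond in one move, so the compounds shown cannot tell which of the two goes with the weakening, or whether the shorter chain alone would give the same result. They also leave open how an ester ending in a plain longer chain, an amine or a carboxylic acid would behave on the core with the free sugar in this assay.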